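A few compounds are considered here, and "the series" means these few. Any claim that something is new, unique, unknown or untested is made for them only; others in the source may bear on it.

Measured in a physicochemical assay, with a stated time of 6 min; a higher number here means a weaker inhibitor, a lower number a stronger inhibitor:

- Compound 1 `O=C(Nc1ccc(I)cc1)Nc1nc(-c2cc3ccccc3o2)cs1`: 62000 nM
- Compound 2 `O=C(Nc1ccc(F)cc1)Nc1nc(-c2cc3ccccc3o2)cs1`: 1130 nM

Compound 2 has the lower of these two numbers, which makes it the stronger inhibitor of the pair. Compound 3 `O=C(Nc1ccc(Br)cc1)Nc1nc(-c2cc3ccccc3o2)cs1` has not yet been measured. It differs from compound 2 in a single group, with bromo in place of fluoro on an aromatic carbon, para to a large group (bromo in place of fluoro on an aromatic carbon).

Among the compounds with values here, one measured step bears on this change, as it exchanges one halogen for another at the same place. Fluoro in place of iodo gave a 55-fold lower number from compound 1 to compound 2 (1.74 log units; beyond the scatter), a large step. Among the halogens, bromine comes after fluorine and before iodine, so part of that step is expected to come back in reverse, giving a higher number than compound 2 has. Within the data shown here, how much is uncertain, as no measured compound shows how the step divides. The expected change is an 8.8-fold higher number from compound 2 to compound 3 (0.95 log units; beyond the scatter), a clear weakening in this assay. For compound 3 the estimated value is 10000 nM, with an expected range from 2500 nM to 45000 nM.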

Compound 3, half-maximal inhibitory concentration: > 200000 nM
Compound 3 ended at the assay's limit; the forecaster's own chance of this, stated with the estimate: 10%; at least 20-fold (1.30 log units) between middle value and limit.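

In this assay, within the data shown here, compound 3 gives > 200000 nM, which is a limit of the assay and not a number, and it is the only compound of the three that stands there: the limit of > 200000 nM in this assay, at which 1 of the 3 values shown sits. Swapping the halogen at this place therefore does not follow the order of the halogens, since the change to bromo gives an at least 170-fold higher number from compound 2 to compound 3 (2.24 log units; beyond the scatter) and also an at least 3.2-fold higher number from compound 1 to compound 3 (0.50 log units; beyond the scatter), which puts bromo past iodo rather than in the middle of the series. Going by these compounds, compound 2, with fluoro, is now the strongest inhibitor of the three and compound 3 the weakest, so the exchange of one heavy atom on this aromatic carbon can shift the number far more than the first pair suggested, and the true size of both new steps remains unknown beyond the bounds printed with them.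

Nothing shown explains why bromo and iodo fall in this order, and three halogens are too few to tell a trend from an irregularity. On these data alone, it also remains open what chloro, a plain hydrogen, or a methyl or methoxy group would give at the same place on the ring.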